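Removing the Chloro Group From Compound 1

The source may report more compounds than this note shows. Statements on the series, on what has been measured and on what is new or still open speak of the compounds shown alone.

Compound 1 `CC(C)N(C(=S)SCc1oc2ccccc2c(=O)c1Cl)C(C)C` is measured in a functional assay on SW480 cells (Homo sapiens) for antiproliferative activity, read by MTT assay, with a stated time of 72 h (on this read-out lower numbers stand for stronger inhibition and higher numbers for weaker inhibition), where compound 1 gives 18100 nM. For the measured compounds named here, of the two numbers known, this is the highest; its nearest neighbour is compound 2 `O=c1c(Cl)c(CSC(=S)N2CCCCC2)oc2ccccc12`, which gives 690 nM. Going by the values given here, the only measured step, a 26-fold lower number from compound 1 to compound 2 (1.42 log units; beyond the scatter), changes the amine on the thiocarbonyl carbon and nothing else. Compound 3 `CC(C)N(C(=S)SCc1cc(=O)c2ccccc2o1)C(C)C` differs from compound 1 at another place: hydrogen in place of chloro on an aromatic carbon. Among the compounds with values here, no measured step touches this position, so the change from compound 1 to compound 2 does not bear on it directly, and the expectation rests on the structural change alone. Removing the chloro is a modest alteration to the shared core, and the estimate is that compound 3 stays near compound 1, with an expected step of a 1.4-fold higher number from compound 1 to compound 3 (0.14 log units; within the scatter) that may not reach beyond the scatter. Compound 3 is therefore expected to give about 25000 nM in this assay, within a range from 6000 nM to 90000 nM.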

Compound 3, half-maximal inhibitory concentration: > 40000 nM
Compound 3: only a limit was reported; the forecaster's own chance of this, stated with the estimate: 20%; middle value at least 1.6-fold (0.20 log units) from the limit.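

Hydrogen in place of chloro on this aromatic carbon weakens the effect in this assay, with an at least 2.2-fold higher number from compound 1 to compound 3 (0.34 log units; beyond the scatter). This step has only a lower end, set by a limit and not by a number: the limit of > 40000 nM in this assay, at which 1 of the 3 values shown sits. Until now, only the amine on the thiocarbonyl carbon had been seen to shift the number, and this result shows that the chloro position matters too, even with the diisopropylamino group left unchanged.

Going by these compounds, it remains open whether another group at this position, such as bromo, methyl or methoxy, would keep the number near that of compound 1. On these data alone, it is also open how the piperidin-1-yl group of compound 2 would fare with hydrogen in place of chloro, as the two changes appear here only separately.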